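The source may report more compounds than this note shows. Statements on the series, on what has been measured and on what is new or still open speak of the compounds shown alone.

Compounds that differ only in the group on an amine nitrogen in a ring make a small, tidy series. In an in vitro ADME assay on microsomes from liver (Homo sapiens) for pharmacokinetics, read by LC-MS, with a stated time of 10 min, tested at 1 uM (a lower number here means slower removal, a higher number faster removal of the compound), compound 1 `Nc1ccccc1NC(=O)/C=C/c1ccc([C@H]2CN(C3COC3)C[C@@H]2C(=O)Nc2ccc(Cl)cc2)cc1` gives 13 mL/min/kg, compound 2 `N#CCN1C[C@H](C(=O)Nc2ccc(Cl)cc2)[C@@H](c2ccc(/C=C/C(=O)Nc3ccccc3N)cc2)C1` gives 17 mL/min/kg and compound 3 `CCN(CC)C(=O)N1C[C@H](C(=O)Nc2ccc(Cl)cc2)[C@@H](c2ccc(/C=C/C(=O)Nc3ccccc3N)cc2)C1` gives 19 mL/min/kg. Compound 3 therefore stands within the usual scatter of both others: the steps are a 1.5-fold higher number from compound 1 to compound 3 (0.16 log units; within the scatter) and a 1.1-fold higher number from compound 2 to compound 3 (0.05 log units; within the scatter).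

Compound 4 `Nc1ccccc1NC(=O)/C=C/c1ccc([C@H]2CN(C3CCOCC3)C[C@@H]2C(=O)Nc2ccc(Cl)cc2)cc1` has not yet been measured. For the measured compounds named here, it keeps the shared core and alters only that nitrogen group: oxan-4-yl in place of diethylcarbamoyl on an amine nitrogen in a ring. In words, this is oxan-4-yl in place of diethylcarbamoyl on an amine nitrogen in a ring.

Going by the values given here, no measured step involves oxan-4-yl itself, so the nearest evidence is the other swaps on the same nitrogen. Besides the two above, there is a 1.3-fold higher number from compound 1 to compound 2 (0.12 log units; within the scatter). None of them goes beyond the scatter, so no step beyond the scatter is expected in this assay. Compound 1, at 13 mL/min/kg, carries oxetan-3-yl, the measured group whose name lies closest to oxan-4-yl, so the expectation leans slightly towards that value. The expected step is a 1.3-fold lower number from compound 3 to compound 4 (0.10 log units; within the scatter). The estimate for compound 4 is 15 mL/min/kg, with an expected range from 8 mL/min/kg to 28 mL/min/kg.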

Compound 4, clearance: 12 mL/min/kg
The estimate for compound 4 lay 1.3-fold (0.10 log units) above the measured number; the measured number falls inside the stated range.
By their numbers in this assay, from the lowest: compounds 4, 1, 2 and 3 (each within the scatter of the next).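

Oxan-4-yl puts a six-membered non-aromatic ring on the amine nitrogen, and in this assay this new group can be set against all three earlier ones: against the open-chain diethylcarbamoyl group the result is (a 1.6-fold lower number from compound 3 to compound 4 (0.20 log units; within the scatter)), against cyanomethyl it is (a 1.4-fold lower number from compound 2 to compound 4 (0.15 log units; within the scatter)), and against oxetan-3-yl it is (a 1.1-fold lower number from compound 1 to compound 4 (0.03 log units; within the scatter)). All three steps lie within the scatter, so four groups that differ in ring, size and atoms cannot be told apart in this assay, and a six-membered ring at this position brings no step beyond the scatter. Nothing available here explains why the readings stay so close across these groups.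

On these data alone, it remains open whether a group of another type on this nitrogen, such as a carboxylic acid, a primary amine or a longer alkyl chain, would give a step beyond the scatter. These compounds also say nothing about changes elsewhere on the shared core, for example in the (4-chlorophenyl)carbamoyl group, where a different swap might move the number more than any swap on the nitrogen has done.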